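Replacing the amino group of compound 1 with hydrogen

This account rests on a few compounds, and the source may have more. Where it says the series, first, only, none or still open, it means among the compounds named here.

Compound 1 `COc1cc(-c2ncnn2-c2cccc(N)c2)cc(OC)c1OC` has been read in a functional assay on HL-60 cells (Homo sapiens) for antiproliferative activity, read by MTT assay, with a stated time of 72 h; on this read-out higher numbers stand for weaker inhibition and lower numbers for stronger inhibition. In this assay compound 1 gives > 10000 nM, which is a limit and not a number. Among the measured compounds shown here, compound 2 `COc1cc(-n2ncnc2-c2ccc(OC(F)(F)F)cc2)cc(OC)c1OC` is the only other compound read so far. In this assay compound 2 gives > 10000 nM, also a limit. For the measured compounds named here, the record therefore amounts to the limit of > 10000 nM in this assay, at which 2 of the 2 values shown sit, and it contains no measured step between compounds.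

Compound 3 `COc1cc(-c2ncnn2-c2ccccc2)cc(OC)c1OC` is the next compound to be read. It departs from compound 1 by one change, hydrogen in place of amino on an aromatic carbon, meta to a large group, so that 3-aminophenyl becomes phenyl. Going by the values given here, no measured pair shows what this exchange does in this assay. The expectation rests only on compound 1, whose reading of > 10000 nM is a limit. The expected change, a step that the limit leaves unreadable from compound 1 to compound 3, is no shift beyond the usual scatter in either direction, and a reading at the same limit is the likeliest outcome. In this assay the estimate for compound 3 is 12000 nM, with an expected range from 4000 nM to 30000 nM.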

Compound 3, half-maximal inhibitory concentration: > 10000 nM
Compound 3 was reported as a limit; the forecaster's own chance of this, stated with the estimate: 80%; the middle value does not contradict the limit.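

Compound 1 and compound 3 are both reported as limits in this assay, so the exchange of amino for hydrogen gives no readable step between them. The compounds shown leave open whether any change to the shared core gives a measured number in this assay, since all readings stand at one limit: the limit of > 10000 nM in this assay, at which 3 of the 3 values shown sit.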